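Swapping Cyclohexyl for Benzyl on the Ring Nitrogen Substituent

The source may report more compounds than this note shows. Statements on the series, on what has been measured and on what is new or still open speak of the compounds shown alone.

Compound 1 `CCCNc1cc(-c2ccccc2)nc2cc(OC)cc(OC)c12` gives 13100 nM in a functional assay on A549 cells (Homo sapiens) for inhibition, read by MTT assay, with a stated time of 72 h; on this read-out higher numbers stand for weaker inhibition and lower numbers for stronger inhibition.
Compound 2 `COc1cc(OC)c2c(NC3CCCCC3)cc(-c3ccccc3)nc2c1` gives 6590 nM in this assay.

Of the two measured numbers, compound 2 carries the lower one, yet the step of a 2.0-fold lower number from compound 1 to compound 2 (0.30 log units; within the scatter) is within the scatter, so the two compounds are not separated by this measurement.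

Compound 3 `COc1cc(OC)c2c(NCc3ccccc3)cc(-c3ccccc3)nc2c1` differs from compound 2 in one place: benzyl in place of cyclohexyl on a nitrogen on an aromatic ring. Going by the values given here, the only measured step that bears on this position is a 2.0-fold lower number from compound 1 to compound 2 (0.30 log units; within the scatter), where the substituent on the same nitrogen was exchanged and the number did not move beyond the scatter. On that single precedent, no step beyond the scatter is expected in this assay for the new exchange either.

Compound 3 is therefore estimated at 6000 nM, with a range from 2000 nM to 18000 nM. The expected step of a 1.1-fold lower number from compound 2 to compound 3 (0.04 log units; within the scatter) reflects this.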

Compound 3, half-maximal inhibitory concentration: 12800 nM
Compound 3: middle estimate off by 2.1-fold (0.33 log units), on the low side; the range from low to high includes it.
By their numbers in this assay, from the lowest: compounds 2, 3 and 1 (each within the scatter of the next).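

In this assay, benzyl in place of cyclohexyl on the nitrogen gives a 1.9-fold higher number from compound 2 to compound 3 (0.29 log units; within the scatter), so replacing the non-aromatic ring with a benzyl group bearing an aromatic ring does not separate the two compounds. Phenyl in place of ethyl on the saturated chain carbon bound to that nitrogen gives a 1.0-fold lower number from compound 1 to compound 3 (0.01 log units; within the scatter), which likewise leaves the two compounds unseparated. With propyl, cyclohexyl and benzyl now compared at this position, every step among them lies within the scatter, and the change to benzyl adds no separation that the earlier pair lacked.

The compounds shown leave open whether a hydroxyethyl chain, a dimethylaminoethyl chain or a carboxylic acid on the chain at this nitrogen would give a step beyond the scatter. No measurement at hand offers an explanation for these numbers.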